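Swapping a benzyl amide for a pyridyl amide

The compounds below may be only part of what the source reports. "The series", "measured", "known", "first", "only" and "open" are said of these compounds alone.

Of the compounds shown here, two have been measured. Compound 1 `CO[C@H]1CC[C@H](NC(=O)c2n[nH]cc2NC(=O)c2c(C)nc3ccccn23)CC1` in an ADME assay on MRC5 cells (Homo sapiens) for inhibition, with a stated time of 72 h (a lower number here means that less compound is needed, a higher number that more compound is needed for the effect), gives 34000 nM. Compound 2 `COc1cccc(OC)c1C(=O)Nc1c[nH]nc1C(=O)NCc1ccccc1`, built on the same core but with different groups on both amide links, in this assay gives 50000 nM, the larger of the two numbers shown; its distance from compound 1, however, lies within the scatter, so the two compounds cannot be told apart on these data.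

Compound 3 `COc1cccc(OC)c1C(=O)Nc1c[nH]nc1C(=O)Nc1ccncc1` differs from compound 2 in a single place: pyridin-4-yl in place of benzyl on an amide-type nitrogen. Among the compounds with values here, no measured pair of compounds differs in exactly this way, and compounds 1 and 2 differ at several places at once, so the data give no direct reading of what this change does in this assay. Compound 3 is therefore expected to remain close to compound 2, with a step of no change at the digits printed from compound 2 to compound 3 (within the scatter) that is not expected to reach beyond the scatter in either direction. The estimate for compound 3 in this assay is 50000 nM, with a range from 20000 nM to 120000 nM.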

Compound 3, half-maximal effective concentration: > 50000 nM
Compound 3: only a limit was reported; the forecaster's own chance of this, stated with the estimate: 35%; the middle value lies on the limit itself.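

In this assay, compound 3 carries the limit > 50000 nM, which is a limit of the assay and not a number. Within the data shown here, the change of benzyl to pyridin-4-yl on the amide-type nitrogen now has its first direct reading, which the earlier compounds could not give, and the step reads a number no lower from compound 2 to compound 3 (the limit leaves the size open), so the swap brings no drop in the number in this assay. How far the number moves stays unreadable because the reading ends at the limit: the limit of > 50000 nM in this assay, at which 1 of the 3 values shown sits.

The compounds shown leave open whether any effect belongs to the ring nitrogen or to the shorter link, since benzylamino gives way to (pyridin-4-yl)amino and both features change in the one step; a phenyl group on the same amide-type nitrogen would separate the two. They also leave open whether a pyridin-3-yl group or a pyridin-2-yl group there would read the same, and a value below the limit would be needed before any size could be given to such a change.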